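Compound 1 to compound 4: a new thiocarbonyl substituent

The source may report more compounds than this note shows. Statements on the series, on what has been measured and on what is new or still open speak of the compounds shown alone.

compound 1 `CCCCCCCCCCCCCCCCOP(=O)(O)OCCSC(=S)N1CCCCCC1` gives > 100000 nM as a limit
compound 2 `CCCCCCCCCCOP(=O)(O)OCCSC(=S)N1CCCCCC1` gives 11400 nM
compound 3 `CCCOP(=O)(O)OCCSC(=S)N1CCCCC1` gives 68000 nM

In a functional assay on MDA-MB-231 cells (Homo sapiens) for inhibition, read by MTT assay, with stated times of 18 h and 4 h (a lower number here means a stronger inhibitor, a higher number a weaker inhibitor), compound 1 gives > 100000 nM as a limit of the assay and not a number. Its standing is therefore the limit of > 100000 nM in this assay, at which 1 of the 3 values shown sits, and nothing firmer.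

Compound 4 `CCCCCCCCCCCCCCCCOP(=O)(O)OCCSC(=S)N1CCN(C)CC1` keeps the chain of compound 1 and differs in one place, with 4-methylpiperazin-1-yl in place of azepan-1-yl on a thiocarbonyl carbon and no other change.

For the measured compounds named here, the only measured step, an at least 8.7-fold lower number from compound 1 to compound 2 (0.94 log units; beyond the scatter), alters the chain and leaves the azepan-1-yl group untouched, so it bears on this change only indirectly. Compound 3 gives 68000 nM but has a different chain as well as a different ring. Going by the values given here, no measured step isolates the exchange at the thiocarbonyl carbon.

With the chain held, compound 4 is expected to remain weak in this assay and may also return only a limit. The expected step, an at least 1.4-fold lower number from compound 1 to compound 4 (0.15 log units; that floor lies within the scatter), is small and uncertain. Compound 4 is estimated at 70000 nM, with an expected range from 20000 nM to 150000 nM.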

Compound 4, half-maximal inhibitory concentration: > 100000 nM
Compound 4: a limit, no number (the forecaster's own chance of this, stated with the estimate: 45%); middle value at least 1.4-fold (0.15 log units) away from the limit.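

In this assay compound 4 gives > 100000 nM, a limit of the assay and not a number. Compound 1 stands at the same limit, so no step can be read between compound 1 and compound 4: the limit of > 100000 nM in this assay, at which 2 of the 4 values shown sit.

The compounds shown leave open whether 4-methylpiperazin-1-yl in place of azepan-1-yl on a thiocarbonyl carbon changes the inhibition at all.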